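Removing the hydroxy from compound 3: working notes

This account rests on a few compounds, and the source may have more. Where it says the series, first, only, none or still open, it means among the compounds named here.

Measured so far in a functional assay on BT-474 cells (Homo sapiens) for cytotoxicity, with a stated time of 72 h; on this read-out higher numbers stand for weaker inhibition and lower numbers for stronger inhibition
- compound 1 (`Oc1ccc(CNC2(c3ccccc3F)CCCC2)cc1CN1CCN(Cc2ccccc2)CC1`) gives 34700 nM
- compound 2 (`CCN(CC)Cc1cc(CNC2(c3ccccc3F)CCCC2)ccc1O`) gives > 100000 nM which is a limit of the assay and not a number
- compound 3 (`Oc1ccc(CNC2(c3ccccc3F)CCCC2)cc1CN1CCCCC1`) gives 35600 nM

Compound 3 lies within the scatter of compound 1, so the two stand level. Compound 4 (`Fc1ccccc1C1(NCc2cccc(CN3CCCCC3)c2)CCCC1`) follows from compound 3 by hydrogen in place of hydroxy on an aromatic carbon and so carries hydrogen in place of hydroxy on an aromatic carbon. Among the measured compounds shown here, the only measured step is an at least 2.8-fold lower number from compound 2 to compound 3 (0.44 log units; beyond the scatter) and it changes another group while the hydroxy stays, so it gives no size for this change. No shift beyond the scatter is therefore expected in this assay although the range must stay wide. The expected step is a 1.1-fold higher number from compound 3 to compound 4 (0.05 log units; within the scatter) and it lies within the scatter. Compound 4 is estimated at 40000 nM within a wide expected range (14000 nM to 100000 nM).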

Compound 4, half-maximal inhibitory concentration: 40000 nM
Estimate against measurement, compound 4: no gap at the digits printed, and the stated range covers the measured number.
By their numbers in this assay, from the lowest: compounds 1, 3 and 4 (each within the scatter of the next). At a limit, above all of these: compound 2.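

Hydrogen in place of hydroxy on this aromatic carbon, ortho to a (piperidin-1-yl)methyl group, gives in this assay a 1.1-fold higher number from compound 3 to compound 4 (0.05 log units; within the scatter), so in this pair the hydroxy can go without a shift beyond the scatter. Among the compounds shown here, compounds 1, 2 and 3 all carry the hydroxy, so this is the first reading of the change. Nothing at hand gives a cause for this step.

Still open, going by these compounds, is whether a methoxy or an amine on this carbon would move the number beyond the scatter. Also open, on these data alone, is whether removing the hydroxy from compound 1 reads the same way.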